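The source may hold more compounds than are shown below. What is called first, only, known or untested is meant among the compounds shown, and "the series" means these compounds.

Series notes. Compound 1 `CCC1(Cc2ccccc2)OS(=O)(=O)C=C1OCc1ccccc1` is the reference point. For the measured compounds named here, in an ADME assay on HEL cells (Homo sapiens) for cytotoxicity, with a stated time of 3 days (on this read-out higher numbers stand for lower toxicity in this test and lower numbers for higher toxicity in this test), compound 1 gives 200000 nM, the only plain number among the three values so far. Compound 2 `CCC1(Cc2ccccc2)OS(=O)(=O)C=C1OCc1ccc([N+](=O)[O-])cc1` carries nitro in place of hydrogen on an aromatic carbon; in this assay compound 2 gives < 200000 nM, which is a limit of the assay and not a number. Compound 3 `CCC1(Cc2ccccc2)OS(=O)(=O)C=C1OCc1ccc(OC)cc1` carries methoxy in place of hydrogen on an aromatic carbon; in this assay compound 3 gives > 200000 nM, again a limit. The step of a number no higher from compound 1 to compound 2 (the limit leaves the size open) rests on (the limit of < 200000 nM in this assay, at which 1 of the 3 values shown sits), and the step of a number no lower from compound 1 to compound 3 (the limit leaves the size open) on (the limit of > 200000 nM in this assay, at which 1 of the 3 values shown sits), so neither size is readable; the step of a number no lower from compound 2 to compound 3 (the limit leaves the size open) likewise leaves its size open.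

Compound 4 `CCC1(Cc2ccccc2)OS(=O)(=O)C=C1OC` differs from compound 1 as follows: hydrogen in place of phenyl on a saturated chain carbon bound to an oxygen on an unsaturated carbon. Going by the values given here, none of the measured steps touches this change; all of them alter the aromatic ring of the benzyl group that is removed here, and all are bounded by limits. Compound 1 and the two limits sit at the same point, so no direction is indicated. For compound 4 the step of no change at the digits printed from compound 1 to compound 4 (within the scatter) is expected to stay within the usual scatter. The estimate for compound 4 in this assay is 200000 nM, in the range 100000 nM to 400000 nM.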

Compound 4, half-maximal cytotoxic concentration: > 200000 nM
Compound 4: only a limit was reported (the forecaster's own chance of this, stated with the estimate: 50%); the middle value sits exactly at the limit.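

In this assay compound 4 gives > 200000 nM, which is a limit of the assay and not a number. The earlier steps shown here changed only a substituent on the aromatic ring of the benzyl group, whereas this change removes the phenyl altogether, and the result is a number no lower from compound 1 to compound 4 (the limit leaves the size open), along with a number no lower from compound 2 to compound 4 (the limit leaves the size open). Losing the phenyl at this position therefore brings no lower number in this test, but none of the sizes can be read, including that of the step between compound 3 and compound 4, and the reading of this position rests on a limit: the limit of > 200000 nM in this assay, at which 2 of the 4 values shown sit.

On these data alone, how far the numbers of compound 3 and compound 4 lie from that of compound 1 stays open, as does the distance of compound 2 on the other side. Also open, as far as these compounds go, is how an amine or a carboxylic acid on the aromatic ring of the benzyl group, or a longer chain in place of the methyl of compound 4, would read in this assay.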